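A few compounds are considered here, and "the series" means these few. Any claim that something is new, unique, unknown or untested is made for them only; others in the source may bear on it.

In a functional assay on CNE-2 cells (Homo sapiens) for antiproliferative activity, read by sulforhodamine B assay, with a stated time of 48 h (a higher number here means a weaker inhibitor, a lower number a stronger inhibitor), compound 1 (`CN(C)c1ccc(/C=C/C(=O)c2ccccc2-c2ccc(F)cc2)cc1`) gives 30 nM. Compound 2 (`COc1ccc(C(=O)/C=C/c2ccccc2-c2ccc(F)nc2)cc1`) gives 13000 nM, and compound 3 (`COc1ccc(C(=O)/C=C/c2ccccc2-c2ccc(F)nc2)cc1OC`) gives 17000 nM. Compound 3 therefore sits level with compound 2 within the scatter, and the number for compound 1 lies far lower than both.

Compound 4 (`COc1cc(C(=O)/C=C/c2ccccc2-c2ccc(F)nc2)ccc1O`) differs from compound 3 by a single change: hydrogen in place of methyl on an oxygen on an aromatic ring. This is hydrogen in place of methyl on an oxygen on an aromatic ring, or methoxy to hydroxy. Among the measured compounds shown here, no measured pair shows this exact change, so the evidence is indirect. For the measured compounds named here, the only measured step between close relatives is a 1.3-fold higher number from compound 2 to compound 3 (0.12 log units; within the scatter), where a methoxy took the place of hydrogen on an aromatic carbon. With so little data, that small step suggests only a modest shift in this assay, in no firmly known direction and with none expected beyond the scatter. The expected step is a 1.3-fold lower number from compound 3 to compound 4 (0.12 log units; within the scatter). For compound 4 the estimated value is 13000 nM, with an expected range of 4500 nM to 35000 nM.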

Compound 4, half-maximal inhibitory concentration: 19000 nM
Estimate against measurement, compound 4: 1.5-fold (0.16 log units) below; the measured number falls inside the stated range.
By their numbers in this assay, from the lowest: compound 1; then compounds 2, 3 and 4 (each within the scatter of the next).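

In this assay, methoxy to hydroxy on this aromatic ring gives a 1.1-fold higher number from compound 3 to compound 4 (0.05 log units; within the scatter), so removing the methyl from this oxygen leaves the number within the scatter. The earlier step, a 1.3-fold higher number from compound 2 to compound 3 (0.12 log units; within the scatter), showed only that adding a methoxy on an aromatic carbon made no change beyond the scatter; this new step shows the same for a change on the oxygen itself, so neither of the two edits to this ring moves the number in these compounds. No measurement is available that explains this flat result.

As far as these compounds go, whether a longer chain on this oxygen, such as ethyl or propyl, or a carboxylic acid on this ring would move the number beyond the scatter remains open. From the compounds shown here alone, it is also open whether methoxy to hydroxy would behave the same way on the core of compound 1.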